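From thiophen-2-yl to 4-methoxyphenyl on a shared core

A few compounds are considered here, and "the series" means these few. Any claim that something is new, unique, unknown or untested is made for them only; others in the source may bear on it.

In a functional assay, read by spectrophotometry, tested at 100 uM (on this read-out higher numbers stand for weaker inhibition and lower numbers for stronger inhibition), the compounds read as follows:
Compound 1 `O=C(/C=C/c1cccc2ccccc12)c1cccc(NC(=O)c2cc(-c3ccncc3)n[nH]2)c1` gives 72100 nM
Compound 2 `Cc1ccc(/C=C/C(=O)c2cccc(NC(=O)c3cc(-c4ccncc4)n[nH]3)c2)cc1` gives 64600 nM
Compound 3 `O=C(/C=C/c1cccs1)c1cccc(NC(=O)c2cc(-c3ccncc3)n[nH]2)c1` gives 70000 nM

Compound 3 has no distinct rank among these three: the step of a 1.0-fold lower number from compound 1 to compound 3 (0.01 log units; within the scatter) and the step of a 1.1-fold higher number from compound 2 to compound 3 (0.03 log units; within the scatter) both leave it level with the others. Compound 4 `COc1ccc(/C=C/C(=O)c2cccc(NC(=O)c3cc(-c4ccncc4)n[nH]3)c2)cc1` has not yet been measured. It carries 4-methoxyphenyl in place of thiophen-2-yl on a double-bonded chain carbon bound to a double-bonded chain carbon, the change being 4-methoxyphenyl in place of thiophen-2-yl on a double-bonded chain carbon bound to a double-bonded chain carbon in full. A third exchange at this place, from naphthalen-1-yl to 4-methylphenyl, gave a 1.1-fold lower number from compound 1 to compound 2 (0.05 log units; within the scatter) and so also stayed small. Given a 1.1-fold higher number from compound 2 to compound 3 (0.03 log units; within the scatter) for the exchange involving the closest measured group, no step beyond the scatter is expected in this assay in either direction. The expected step is a 1.1-fold lower number from compound 3 to compound 4 (0.03 log units; within the scatter) on this estimate. The estimated value for compound 4 is 65000 nM with an expected range of 35000 nM to 100000 nM in this read-out.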

Compound 4, half-maximal inhibitory concentration: 54600 nM
Compound 4: middle estimate off by 1.2-fold (0.08 log units), on the high side, within the range that was stated.
By their numbers in this assay, from the lowest: compounds 4, 2, 3 and 1 (each within the scatter of the next).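

With 4-methoxyphenyl, this place now carries a group with an oxygen atom, yet in this assay the exchange for thiophen-2-yl stays within the scatter (a 1.3-fold lower number from compound 3 to compound 4 (0.11 log units; within the scatter)). The same holds for the smallest change in the set, methoxy in place of methyl on an aromatic carbon (a 1.2-fold lower number from compound 2 to compound 4 (0.07 log units; within the scatter)), and for the exchange with naphthalen-1-yl (a 1.3-fold lower number from compound 1 to compound 4 (0.12 log units; within the scatter)). Across the four compounds, then, this place shows no step beyond the scatter, whichever of the four groups it carries.

On these data alone, whether an amine or a carboxylic acid on the aromatic ring, or a saturated alkyl chain in place of that ring, would move the number remains open. Nothing available explains why these steps stay so small.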